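This account rests on a few compounds, and the source may have more. Where it says the series, first, only, none or still open, it means among the compounds named here.

Measured compounds in a functional assay on OVCAR-3 cells (Homo sapiens) for inhibition, read by sulforhodamine B assay, with a stated time of 48 h; a higher number here means a weaker inhibitor of growth, a lower number a stronger inhibitor of growth:

Compound 1, `CC1=CC[C@H](C(C)(C)NC(=S)N/N=C/c2ccc(F)cc2)CC1`: in this assay compound 1 gives > 100000 nM, which is a limit of the assay and not a number.
Compound 2, `CC1=CC[C@H](C(C)(C)NC(=S)N/N=C/c2cccc(Cl)c2)CC1`: in this assay compound 2 gives 80500 nM.

Within the data shown here, compound 2 thus carries the only numerical value in this assay; the remaining value in the set is a limit. Among the measured compounds shown here, the single measured step, an at least 1.2-fold lower number from compound 1 to compound 2 (0.09 log units; that floor lies within the scatter), rests on one side on (the limit of > 100000 nM in this assay, at which 1 of the 2 values shown sits), so its floor says little about the effect of an aryl change on the carbon with a double bond to nitrogen.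

Compound 3, `CC1=CC[C@H](C(C)(C)NC(=S)N/N=C/c2cccs2)CC1`, is not yet measured. It differs from compound 2 by thiophen-2-yl in place of 3-chlorophenyl on a carbon with a double bond to nitrogen. For the measured compounds named here, no measured step exchanges an aryl for a heteroaryl at that position, so the only guide is the shallow step from compound 1 to compound 2, whose true size is unknown beyond its floor. The expectation in this assay is therefore for little change beyond the scatter, with the estimated step of a 1.1-fold higher number from compound 2 to compound 3 (0.05 log units; within the scatter), and a real chance that only a limit is returned. Compound 3 is estimated at 90000 nM, with a range from 35000 nM to 200000 nM.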

Compound 3, concentration for total growth inhibition: 35100 nM
Compound 3: middle estimate off by 2.6-fold (0.41 log units), on the high side; the range from low to high includes it.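

Among these compounds, at the carbon with a double bond to nitrogen, the choice of ring does shift the read-out in this assay: thiophen-2-yl in place of 3-chlorophenyl gives a 2.3-fold lower number from compound 2 to compound 3 (0.36 log units; beyond the scatter), the only step with a number at both ends. Thiophen-2-yl in place of 4-fluorophenyl gives an at least 2.8-fold lower number from compound 1 to compound 3 (0.45 log units; beyond the scatter), so the five-membered aromatic ring with its hetero atom stands ahead of both six-membered aromatic rings shown, though this second step is only a floor. Compound 1 sits at a limit of the assay, which leaves the full size of that step unknown: the limit of > 100000 nM in this assay, at which 1 of the 3 values shown sits.

The compounds shown do not separate the ring size from the sulfur atom, a question that furan-2-yl, thiophen-3-yl or unsubstituted phenyl at this position would address. Also open, as far as these compounds go, is whether a pyridin-3-yl ring, or a ring carrying an amine or a carboxylic acid, would extend the step seen with thiophen-2-yl, and how any of these changes would read with the rest of the shared core altered.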